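The source may hold more compounds than are shown below. What is called first, only, known or untested is meant among the compounds shown, and "the series" means these compounds.

Compound 2 `O=C(CCC(=O)OCCCCCCSc1ccc([N+](=O)[O-])c2nonc12)Nc1ccccc1Cl` gives the highest of the two numbers in an assay on isolated protein for inhibition of glutathione S-transferase Mu 2 (Homo sapiens), with a stated time of 10 min; on this read-out higher numbers stand for weaker inhibition and lower numbers for stronger inhibition: compound 2 gives 330 nM, while compound 1 `O=C(O)CCC(=O)OCCCCCCSc1ccc([N+](=O)[O-])c2nonc12` gives 160 nM, the step being a 2.1-fold higher number from compound 1 to compound 2 (0.31 log units; beyond the scatter). Compound 3 `Cc1ccccc1NC(=O)CCC(=O)OCCCCCCSc1ccc([N+](=O)[O-])c2nonc12` differs from compound 2 by methyl in place of chloro on an aromatic carbon. Among the measured compounds shown here, no measured step bears on this change; the single known step swaps hydroxy for (2-chlorophenyl)amino on a carbonyl carbon and tells nothing about exchanging one aromatic substituent for another. The expected step is therefore within the usual scatter, in no fixed direction: no change at the digits printed from compound 2 to compound 3 (within the scatter). Compound 3 is estimated at 330 nM in this assay, between 150 nM and 720 nM.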

Compound 3, half-maximal inhibitory concentration: 440 nM
The estimate for compound 3 lay 1.3-fold (0.12 log units) below the measured number; the measured number falls inside the stated range.
By their numbers in this assay, from the lowest: compound 1; then compounds 2 and 3 (each within the scatter of the next).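

In this assay, putting methyl in place of chloro on the aromatic carbon ortho to a large group gives a 1.3-fold higher number from compound 2 to compound 3 (0.12 log units; within the scatter) and so does not separate these two groups at this place. With methyl on the ring, replacing the hydroxy of the free acid still raises the number, with a 2.8-fold higher number from compound 1 to compound 3 (0.44 log units; beyond the scatter) and the step now read for a second aryl amide. Nothing measured here explains either step.
From the compounds shown here alone, whether a methoxy group, a trifluoromethyl group or an amine at this place would move the number remains open. So does the effect of a longer chain.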